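The source may report more compounds than this note shows. Statements on the series, on what has been measured and on what is new or still open speak of the compounds shown alone.

Compound 1, `FC(F)(F)c1ccc(CSc2nc(N3CCCCC3)c3ccccc3n2)cc1`: in a functional assay on MCF7 cells (Homo sapiens) for cytotoxicity, read by MTT assay, with a stated time of 72 h (a higher number here means a weaker inhibitor, a lower number a stronger inhibitor), compound 1 gives > 50000 nM, which is a limit of the assay rather than a number.
Compound 2, `O=[N+]([O-])c1cccc(Nc2nc(SCc3ccc(C(F)(F)F)cc3)nc3ccccc23)c1`: in this assay compound 2 gives > 50000 nM, again a limit.
Compound 3, `Cc1ccc(Nc2nc(SCc3ccc(C(F)(F)F)cc3)nc3ccccc23)cc1`: in this assay compound 3 gives > 50000 nM, also a limit.

Compound 3 therefore stands where every measured compound stands: at the limit of > 50000 nM in this assay, at which 3 of the 3 values shown sit. None of the three shows a number, only a boundary the assay could not see beyond.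

Compound 4, `Fc1ccc(Nc2nc(SCc3ccc(C(F)(F)F)cc3)nc3ccccc23)cc1Cl`, differs from compound 3 by 3-chloro-4-fluorophenyl in place of 4-methylphenyl on a nitrogen on an aromatic ring. The step most like this one is a step that the two limits leave unreadable from compound 2 to compound 3, which also swaps the group on that nitrogen; the two other steps, a step that the two limits leave unreadable from compound 1 to compound 2 and a step that the two limits leave unreadable from compound 1 to compound 3, replace the whole group on the aromatic carbon. All three are hidden by the limits, so no size can be read from them.

The step from compound 3 to compound 4 is therefore expected to be a step that the limit leaves unreadable from compound 3 to compound 4, with no readable change. Compound 4 is estimated at 60000 nM, in a range from 30000 nM to 150000 nM, most likely reported as a limit once more.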

Compound 4, half-maximal inhibitory concentration: 23000 nM
Beside the measured number, compound 4's estimate is 2.6-fold (0.42 log units) above it, outside the stated range (below it).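

Compound 4 is the first compound shown to give a number in this assay rather than a limit, so the group on this nitrogen can now be seen to affect the result. Placing 3-chloro-4-fluorophenyl there gives an at least 2.1-fold lower number from compound 3 to compound 4 (0.33 log units; beyond the scatter), and the comparison with the 3-nitrophenyl compound gives an at least 2.1-fold lower number from compound 2 to compound 4 (0.33 log units; beyond the scatter), while the wider change from the piperidin-1-yl compound gives an at least 2.1-fold lower number from compound 1 to compound 4 (0.33 log units; beyond the scatter). Each size is only a minimum, and the steps among compound 1, compound 2 and compound 3 cannot be read, for the same reason: the limit of > 50000 nM in this assay, at which 3 of the 4 values shown sit.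

From the compounds shown here alone, it remains open whether a phenyl ring carrying only the chlorine or only the fluorine would give the same lower number. Also open, going by these compounds, is how a carboxylic acid on that ring, or a longer chain on that nitrogen in place of the ring, would read.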